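A few compounds are considered here, and "the series" means these few. Any claim that something is new, unique, unknown or untested is made for them only; others in the source may bear on it.

Measured so far:
compound 1, `Cc1ccccc1S(=O)(=O)Nc1ccc(-c2nc3ccccc3o2)cc1`, gives 85000 nM in an assay on cells for inhibition of HSP60/HSP10 (Homo sapiens), with a stated time of 60 min; a higher number here means a weaker inhibitor, a lower number a stronger inhibitor
compound 2, `O=S(=O)(Nc1ccc(-c2nc3ccccc3o2)cc1)c1ccc(Cl)s1`, gives 31000 nM in this assay
compound 3, `O=S(=O)(Nc1ccc(-c2nc3cc(NS(=O)(=O)c4ccc(O)cc4)ccc3o2)cc1)c1ccc(O)cc1`, gives 14000 nM in this assay

Compound 3 stands at the lowest of the three numbers; compound 2 is the nearest to it, with a higher number, and compound 1 the furthest, with the highest number of the set. Compound 4, `O=S(=O)(Nc1ccc(-c2nc3ccccc3o2)cc1)c1ccc(O)cc1`, is the next compound to be measured. Compared with compound 3 the change is hydrogen in place of ((4-hydroxyphenyl)sulfonyl)amino on an aromatic carbon. Within the data shown here, no measured step touches that position. The only step shown, a 2.7-fold lower number from compound 1 to compound 2 (0.44 log units; beyond the scatter), changes the group on the sulfonyl sulfur and is modest in size, so it says little about removing a whole sulfonamide from the fused system. What the numbers do show is that compound 1 and compound 2, which carry a single sulfonamide as compound 4 does, both sit above compound 3. Compound 4 is therefore expected to give a higher number than compound 3, a step of a 2.5-fold higher number from compound 3 to compound 4 (0.40 log units; beyond the scatter) in this assay, landing in the region of compound 2. The estimate for compound 4 is 35000 nM, with a range from 12000 nM to 100000 nM.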

Compound 4, half-maximal inhibitory concentration: 78000 nM
Estimate against measurement, compound 4: 2.2-fold (0.35 log units) below; low and high end bracket the measured number.
By their numbers in this assay, from the lowest: compound 3; then compound 2; then compounds 4 and 1 (each within the scatter of the next).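

In this assay, among these compounds, a 5.6-fold higher number from compound 3 to compound 4 (0.75 log units; beyond the scatter) gives the first reading at this aromatic carbon of the fused system: with hydrogen there in place of ((4-hydroxyphenyl)sulfonyl)amino, the number rises beyond the scatter, so within this pair the larger group goes with the lower number. Among the compounds shown here, with hydrogen at that carbon, the group on the sulfonyl sulfur can now be compared across three compounds: 4-hydroxyphenyl in place of 5-chlorothiophen-2-yl gives a 2.5-fold higher number from compound 2 to compound 4 (0.40 log units; beyond the scatter), beyond the scatter, while 4-hydroxyphenyl in place of 2-methylphenyl gives a 1.1-fold lower number from compound 1 to compound 4 (0.04 log units; within the scatter), within the scatter, which leaves 5-chlorothiophen-2-yl as the only one of these groups that separates from the others. No measurement at hand accounts for either the step at the aromatic carbon or the steps at the sulfonyl sulfur.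

The compounds shown leave open whether the whole ((4-hydroxyphenyl)sulfonyl)amino group is needed for the lower number, or whether a simple amine or an acetamide on the same aromatic carbon would give a similar value. They also leave open whether a 5-chlorothiophen-2-yl group in that added sulfonamide, or on the other sulfonyl sulfur alongside it, would move the number further.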